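Chloro for fluoro on the shared core: compound 3

The compounds below may be only part of what the source reports. "The series", "measured", "known", "first", "only" and "open" are said of these compounds alone.

Measured so far, in a functional assay on HL-60 cells (Homo sapiens) for cytotoxicity, read by luminescence and CellTiter-Glo, with a stated time of 3 days; on this read-out higher numbers stand for weaker inhibition and lower numbers for stronger inhibition:
compound 1 `N#Cc1ccc(NC(=O)c2ccc(F)cc2O)cc1` — 1380 nM
compound 2 `O=C(Nc1ccc(C(F)(F)F)cc1)c1ccc(F)cc1O` — 680 nM

Among the measured compounds shown here, compound 1 gives the highest of the two numbers in this assay; its nearest neighbour is compound 2, and the step of a 2.0-fold lower number from compound 1 to compound 2 (0.31 log units; beyond the scatter) is the only change measured so far.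

Compound 3 `N#Cc1ccc(NC(=O)c2ccc(Cl)cc2O)cc1` has not been measured. Against compound 1 it differs in one place: chloro in place of fluoro on an aromatic carbon. The exchange sits on an aromatic carbon of a six-membered aromatic ring of carbon only, meta to a hydroxy group and para to a large group, so it lies on the other ring from the change measured between compound 1 and compound 2.

For the measured compounds named here, no measured step bears on this exchange. The step of a 2.0-fold lower number from compound 1 to compound 2 (0.31 log units; beyond the scatter) concerns trifluoromethyl in place of cyano on a different ring and says nothing about chloro in place of fluoro. Going by the values given here, with no relevant step to go on, the expectation for compound 3 is a step of a 1.3-fold lower number from compound 1 to compound 3 (0.10 log units; within the scatter) that stays within the scatter, in no particular direction, though the range must be kept wide.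

Compound 3 is therefore estimated at 1100 nM in this assay, within 400 nM to 3000 nM.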

Compound 3, half-maximal inhibitory concentration: 1300 nM
For compound 3 the middle estimate is 1.2-fold (0.07 log units) below the measured one; low and high end bracket the measured number.
By their numbers in this assay, from the lowest: compounds 2, 3 and 1 (each within the scatter of the next, the first and the last beyond it).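

In this assay, chloro in place of fluoro on the aromatic carbon meta to a hydroxy group and para to a large group gives a 1.1-fold lower number from compound 1 to compound 3 (0.03 log units; within the scatter) and so does not separate the two halogens at this position. Among the compounds shown here, this is the first exchange on this ring of the shared core, and it stays within the scatter, whereas the only other measured step, a 2.0-fold lower number from compound 1 to compound 2 (0.31 log units; beyond the scatter), lies beyond it on the other ring. No measured evidence speaks to the reason for this result.

The compounds shown leave open whether a group other than a halogen at this position, such as an amine, a methoxy group or a carboxylic acid, would move the number beyond the scatter in either direction. They also leave open whether chloro and fluoro stay equivalent at this position when trifluoromethyl replaces the cyano group on the other ring, since the two exchanges appear only separately, each against compound 1.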